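Removing the Allyl from a Thioether: An Expected Null Step

The compounds below may be only part of what the source reports. "The series", "measured", "known", "first", "only" and "open" are said of these compounds alone.

Compound 1, `Cc1nc(-c2ccccc2)n2c(O)nncc12`: in a functional assay for inhibition, with Homo sapiens as the target (a lower number here means a stronger inhibitor, a higher number a weaker inhibitor), compound 1 reaches only the assay limit of > 48000 nM.
Compound 2, `Sc1nncc2cnc(-c3ccccc3)n12`: in this assay compound 2 likewise gives only the limit > 48000 nM.
Compound 3, `C=CCSc1nncc2c(C)nc(-c3ccccc3)n12`: in this assay compound 3 also stops at the limit > 48000 nM.

Among the measured compounds shown here, compound 3 thus stands exactly where every value shown stands: the limit of > 48000 nM in this assay, at which 3 of the 3 values shown sit, so no compound is separated from another. For the measured compounds named here, the one measured step, a step that the two limits leave unreadable from compound 1 to compound 3, stays unreadable. Compound 4, `Cc1nc(-c2ccccc2)n2c(S)nncc12`, differs from compound 3 by hydrogen in place of allyl on a sulfur. Compound 2 carries the same sulfanyl group on a core without the methyl and also reaches only a limit. Nothing shown bears on this change in a readable way, so the expectation is no step beyond the scatter, with compound 4 expected to stay at the limit. The estimated step is a step that the limit leaves unreadable from compound 3 to compound 4, giving an expected value for compound 4 of 60000 nM, between 20000 nM and 200000 nM.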

Compound 4, half-maximal inhibitory concentration: > 48000 nM
Compound 4: only a limit was reported (the forecaster's own chance of this, stated with the estimate: 85%); the middle value is on the limit's open side.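

Compound 4 gives only a limit, so its steps from compound 1, compound 2 and compound 3 cannot be read: the limit of > 48000 nM in this assay, at which 4 of the 4 values shown sit.

The compounds shown leave open which change to the shared core, if any, would give a readable value in this assay.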